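Cytotoxicity notes on a bicyclic amine series

The source may report more compounds than this note shows. Statements on the series, on what has been measured and on what is new or still open speak of the compounds shown alone.

compound 1, `CCCCc1csc(CN[C@@H]2C[C@H]3C[C@@H]([C@H]2C)C3(C)C)c1`: 12500 nM
compound 2, `C[C@H]1[C@H](NCc2cncs2)C[C@H]2C[C@@H]1C2(C)C`: > 100000 nM
compound 3, `C[C@H]1[C@H](NCc2ccc(Cl)s2)C[C@H]2C[C@@H]1C2(C)C`: not yet measured

In an ADME assay on MDCK cells (Canis lupus familiaris) for cytotoxicity, read by microscopy, with a stated time of 48 h (a higher number here means that more compound is tolerated, a lower number that less compound is tolerated), compound 1 gives 12500 nM. For compound 2 the result is only a limit, > 100000 nM, which is the limit of > 100000 nM in this assay, at which 1 of the 2 values shown sits. Compound 2 thus stands at the edge of what was measured, with no number of its own. Compound 3 carries 5-chlorothiophen-2-yl in place of 1,3-thiazol-5-yl on a saturated chain carbon bound to an amine nitrogen. For the measured compounds named here, no measured pair isolates this change, so its size is open. A shift toward less tolerated compound is expected, estimated as an at least 2.5-fold lower number from compound 2 to compound 3 (0.39 log units; beyond the scatter) in this assay. Compound 3 is expected to give 40000 nM, within 12500 nM to 100000 nM.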

Compound 3, minimum cytotoxic concentration: 25000 nM
Compound 3: middle estimate off by 1.6-fold (0.20 log units), on the high side, within the range that was stated.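

In this assay, the group on the saturated chain carbon bound to an amine nitrogen clearly affects how much compound is tolerated: 5-chlorothiophen-2-yl in place of 1,3-thiazol-5-yl gives an at least 4.0-fold lower number from compound 2 to compound 3 (0.60 log units; beyond the scatter). The earlier compounds shown here offered no step at this place. Going by these compounds, the true size of this step stays open, since compound 2 has a limit and not a number: the limit of > 100000 nM in this assay, at which 1 of the 3 values shown sits.

The compounds shown do not separate the chlorine from the change of ring. An unsubstituted thiophen-2-yl group at this place would make that separation.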